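Two hydrazones, one open question

This account rests on a few compounds, and the source may have more. Where it says the series, first, only, none or still open, it means among the compounds named here.

Measured in a functional assay on A549 cells (Homo sapiens) for inhibition, read by sulforhodamine B assay, with a stated time of 48 h; a lower number here means a stronger inhibitor of growth, a higher number a weaker inhibitor of growth:
- compound 1 `O=C(Cc1csc2nc(-c3ccc(Br)cc3)cn12)N/N=C/c1ccccc1`: 40700 nM
- compound 2 `O=C(Cc1csc2nc(-c3ccc(Br)cc3)cn12)N/N=C/c1ccc(O)cc1`: 33900 nM

In this assay, going by the values given here, compound 2 gives 33900 nM, which lies within the scatter of compound 1, the only other compound measured. Compound 3 `COc1cccc(OC)c1/C=N/NC(=O)Cc1csc2nc(-c3ccc(Br)cc3)cn12` carries a new group: 2,6-dimethoxyphenyl in place of 4-hydroxyphenyl on a carbon with a double bond to nitrogen. Among the compounds with values here, only one measured step bears on this change, a 1.2-fold lower number from compound 1 to compound 2 (0.08 log units; within the scatter), where hydroxy replaced hydrogen on an aromatic carbon. That step stayed within the scatter, but it says nothing directly about 2,6-dimethoxyphenyl. No direction can therefore be argued, and no change beyond the scatter is expected. The expected step is a 1.0-fold lower number from compound 2 to compound 3 (0.01 log units; within the scatter). Compound 3 is estimated at 33000 nM, with an expected range of 16000 nM to 70000 nM.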

Compound 3, concentration for total growth inhibition: 38900 nM
For compound 3 the middle estimate is 1.2-fold (0.07 log units) below the measured one, and the stated range covers the measured number.
By their numbers in this assay, from the lowest: compounds 2, 3 and 1 (each within the scatter of the next).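

In this assay, putting 2,6-dimethoxyphenyl in place of 4-hydroxyphenyl on the carbon with a double bond to nitrogen gives a 1.1-fold higher number from compound 2 to compound 3 (0.06 log units; within the scatter) and putting it in place of phenyl gives a 1.0-fold lower number from compound 1 to compound 3 (0.02 log units; within the scatter). Across these three compounds, then, a group with more heavy atoms and no hydrogen-bond donor leaves the number within the scatter. No supporting measurement is available to explain this result. Still open, on these data alone, is whether an amine or a carboxylic acid on this ring, or a longer chain in its place, would move the number beyond the scatter.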